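The source may hold more compounds than are shown below. What is called first, only, known or untested is meant among the compounds shown, and "the series" means these compounds.

In an ADME assay on microsomes (Homo sapiens) for metabolic stability (a lower number here means slower removal, a higher number faster removal of the compound), compound 3 `CNC(=O)[C@@H]1CCCN1S(=O)(=O)c1ccc(Cl)c(COc2cccc3c(-c4cncn4C)cc(C)nc23)c1Cl` gives 33.3 mL/min/kg and compound 1 `CNC(=O)[C@@H]1CCCN1S(=O)(=O)c1ccc(Cl)c(COc2cccc3c(-n4ccnc4)cc(C)nc23)c1Cl` gives 33.3 mL/min/kg, together the lowest of the three numbers, while compound 2 `CNC(=O)[C@@H]1CCCN1S(=O)(=O)c1ccc(Cl)c(COc2cccc3c(C(F)(F)F)cc(C)nc23)c1Cl` gives 250 mL/min/kg. Compound 4 `CNC(=O)[C@@H]1CCCN1S(=O)(=O)c1ccc(Cl)c(COc2cccc3c(-c4cncn4C)cc(C(C)C)nc23)c1Cl` keeps the 1-methyl-1H-imidazol-5-yl group of compound 3 and carries isopropyl in place of methyl next to the ring nitrogen (isopropyl in place of methyl on an aromatic carbon). The measured steps all change a different place: no change at the digits printed from compound 1 to compound 3 (within the scatter), a 7.5-fold higher number from compound 1 to compound 2 (0.88 log units; beyond the scatter) and a 7.5-fold lower number from compound 2 to compound 3 (0.88 log units; beyond the scatter). None of them gives a direct size for this change, so only a small move towards a higher number in this assay is expected, perhaps within the scatter. The expected step is a 1.5-fold higher number from compound 3 to compound 4 (0.18 log units; within the scatter). For compound 4 the estimate is 50 mL/min/kg, with an expected range of 25 mL/min/kg to 110 mL/min/kg.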

Compound 4, clearance: 33.3 mL/min/kg
Beside the measured number, compound 4's estimate is 1.5-fold (0.18 log units) above it; low and high end bracket the measured number.
By their numbers in this assay, from the lowest: compounds 1, 3 and 4 (each within the scatter of the next); then compound 2.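

In this assay, isopropyl in place of methyl next to the ring nitrogen gives no change at the digits printed from compound 3 to compound 4 (within the scatter). Among these compounds, the earlier steps all changed another place, so this is the first reading at this position: with the 1-methyl-1H-imidazol-5-yl group present, the larger isopropyl leaves clearance within the scatter. No evidence is available that bears on why this is so.

From the compounds shown here alone, it remains open whether the same holds with trifluoromethyl in place of the 1-methyl-1H-imidazol-5-yl group. Going by these compounds, it is also open whether a longer chain, an amine or a carboxylic acid at this position would leave the number unmoved.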